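A few compounds are considered here, and "the series" means these few. Any claim that something is new, unique, unknown or untested is made for them only; others in the source may bear on it.

Working notes on the series. Compound 1 `Cc1cc(O)c(C(c2cn([C@H]3C[C@H](O)[C@@H](CO)O3)c(=O)[nH]c2=O)c2c(O)cc(C)oc2=O)c(=O)o1`, compound 2 `Cc1cc2c(c(=O)[nH]1)C(c1cn([C@H]3C[C@H](O)[C@@H](CO)O3)c(=O)[nH]c1=O)C(C#N)=C(N)O2` and compound 3 `Cc1cc2c(c(=O)n1C)C(c1cn([C@H]3C[C@H](O)[C@@H](CO)O3)c(=O)[nH]c1=O)C(C#N)=C(N)O2` share the deoxynucleoside unit; compound 4 `CCn1c(C)cc2c(c1=O)C(c1cn([C@H]3C[C@H](O)[C@@H](CO)O3)c(=O)[nH]c1=O)C(C#N)=C(N)O2` is the unmeasured member. In an ADME assay on HEL cells (Homo sapiens) for cytotoxicity (on this read-out higher numbers stand for lower toxicity in this test and lower numbers for higher toxicity in this test), compound 1 gives 1800 nM. For compound 2 only a limit of this assay is recorded, > 100000 nM. For compound 3 likewise only a limit is recorded, > 100000 nM. The step that the two limits leave unreadable from compound 2 to compound 3 therefore cannot be sized, since the limit of > 100000 nM in this assay, at which 2 of the 3 values shown sit, holds both ends of it. Compound 3 thus stands at the upper limit of this assay, with no number of its own and one further value of the three also sitting at that limit.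

Compound 4 differs from compound 3 by methyl in place of hydrogen on a saturated chain carbon bound to an aromatic nitrogen, that is, methyl to ethyl when the difference is read one bond further out. Among the measured compounds shown here, only the step from compound 2 to compound 3 bears on this part of the molecule, and that step is unreadable. For the measured compounds named here, no measured step on this position gives a direction, so no change beyond the scatter is expected. For compound 4 the expected value in this assay is 100000 nM, in the range 40000 nM to 250000 nM. The expected step of a number no higher from compound 3 to compound 4 (the limit leaves the size open) is accordingly estimated to stay within the scatter, with a limit the more likely outcome.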

Compound 4, half-maximal cytotoxic concentration: > 100000 nM
Compound 4 ended at the assay's limit; the forecaster's own chance of this, stated with the estimate: 70%; the middle value lies on the limit itself.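

No new step can be read in this assay among compound 2, compound 3 and compound 4, because all three stand at the same limit: the limit of > 100000 nM in this assay, at which 3 of the 4 values shown sit. The compounds shown leave open whether methyl or ethyl in place of hydrogen on the aromatic nitrogen changes the half-maximal cytotoxic concentration at all.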